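A few compounds are considered here, and "the series" means these few. Any claim that something is new, unique, unknown or untested is made for them only; others in the source may bear on it.

Three esters sharing one core were measured in a functional assay on DU-145 cells (Homo sapiens) for cytotoxicity, read by MTT assay; a lower number here means a stronger inhibitor, a higher number a weaker inhibitor:
compound 1 `CCC(C)(O)CC(=O)O[C@H](CC=C(C)C)C1=CC(=O)c2c(O)ccc(O)c2C1=O` gives 16000 nM;
compound 2 `CC(C)=CC[C@@H](OC(=O)C1CCOC1)C1=CC(=O)c2c(O)ccc(O)c2C1=O` gives 47500 nM;
compound 3 `CC(C)=CC[C@@H](OC(=O)CCO)C1=CC(=O)c2c(O)ccc(O)c2C1=O` gives 55300 nM.

Compound 3 thus carries the highest number of the three, although the step of a 1.2-fold higher number from compound 2 to compound 3 (0.07 log units; within the scatter) lies within the scatter, while the step of a 3.5-fold higher number from compound 1 to compound 3 (0.54 log units; beyond the scatter) lies beyond it. Compound 4 `CCCC(CC(=O)O[C@H](CC=C(C)C)C1=CC(=O)c2c(O)ccc(O)c2C1=O)OC(C)=O` has not yet been measured. It differs from compound 3 in one place: 1-acetoxybutyl in place of hydroxymethyl on a saturated chain carbon bound to a carbonyl carbon. Among the measured compounds shown here, two measured steps bear on this. The step of a 3.5-fold higher number from compound 1 to compound 3 (0.54 log units; beyond the scatter) shows that going from 1-hydroxy-1-methylpropyl to hydroxymethyl on a saturated chain carbon bound to a carbonyl carbon raised the number modestly; the step of a 1.2-fold higher number from compound 2 to compound 3 (0.07 log units; within the scatter) shows that going from oxolan-3-yl to 2-hydroxyethyl changed nothing beyond the scatter. Compound 4 moves back toward a longer chain, now one without a hydrogen-bond donor. Because the longer chain of compound 1 goes with 16000 nM, a modest lowering of the number is expected for compound 4, about a 2.8-fold lower number from compound 3 to compound 4 (0.44 log units; beyond the scatter). The estimate for compound 4 is therefore 20000 nM, with a range from 7000 nM to 60000 nM.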

Compound 4, half-maximal inhibitory concentration: 55700 nM
The estimate for compound 4 lay 2.8-fold (0.44 log units) below the measured number; low and high end bracket the measured number.
By their numbers in this assay, from the lowest: compound 1; then compounds 2, 3 and 4 (each within the scatter of the next).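

In this assay replacing hydroxymethyl with the much larger 1-acetoxybutyl on a saturated chain carbon bound to a carbonyl carbon gives a 1.0-fold higher number from compound 3 to compound 4 (0.00 log units; within the scatter) and leaves the number where it was, while 2-acetoxypentyl in place of oxolan-3-yl on a carbonyl carbon gives a 1.2-fold higher number from compound 2 to compound 4 (0.07 log units; within the scatter) with the same outcome, so a longer chain at this position does not by itself bring the number down. Set against 1-hydroxy-1-methylpropyl, the 1-acetoxybutyl group gives a 3.5-fold higher number from compound 1 to compound 4 (0.54 log units; beyond the scatter) so the lower number seen with that group goes with its particular make-up and not with chain length alone. Nothing measured in this set offers a reason for these numbers.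

The compounds shown leave open whether the hydroxyl or the methyl of 1-hydroxy-1-methylpropyl is the part that matters, as no compound here separates the two. Also open, from the compounds shown here alone, is how an amine, a carboxylic acid or a plain butyl chain without the acetoxy group would read at this position.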